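Chloro on the phenyl of compound 1: expected tolerance

The source may hold more compounds than are shown below. What is called first, only, known or untested is meant among the compounds shown, and "the series" means these compounds.

- compound 1 `Cc1cc(-c2ccccc2)cc(C)c1Oc1cc(N)nc(Nc2ccc(C#N)cc2)n1` gives 25600 nM
- compound 2 `Cc1cc(-c2ccc(C#N)c(C#N)c2)ccc1Oc1cc(N)nc(Nc2ccc(C#N)cc2)n1` gives 76700 nM
- compound 3 `Cc1cc(Oc2cc(N)nc(Nc3ccc(C#N)cc3)n2)ccc1-c1ccc(C#N)cc1` gives 34300 nM

In a toxicity assay on MT4 cells (Homo sapiens) for cytotoxicity, read by MTT assay (a higher number here means that more compound is tolerated, a lower number that less compound is tolerated), compound 1 gives 25600 nM and stands with compound 3 at 34300 nM, the two values lying within the scatter of each other. Compound 2 at 76700 nM lies beyond the scatter above compound 1.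

Compound 4 `Cc1cc(-c2cccc(Cl)c2)cc(C)c1Oc1cc(N)nc(Nc2ccc(C#N)cc2)n1` has not yet been measured. It departs from compound 1 by a single change, (chloro in place of hydrogen on an aromatic carbon), in which chloro takes the place of hydrogen on an aromatic carbon, meta to a large group, so that phenyl becomes 3-chlorophenyl.

For the measured compounds named here, no two measured compounds differ in one place only, so the series offers no direct precedent for this change. The values do stay in a fairly narrow band across three differing structures, from compound 1 at 25600 nM to compound 2 at 76700 nM in this assay. On that basis a small downward shift is expected, not beyond the scatter. The estimated step is a 1.3-fold lower number from compound 1 to compound 4 (0.11 log units; within the scatter) for this one substitution. Compound 4 is expected at 20000 nM, with an estimated range from 7000 nM to 60000 nM.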

Compound 4, half-maximal cytotoxic concentration: 22300 nM
Compound 4: the middle estimate sits 1.1-fold (0.05 log units) below what was measured; low and high end bracket the measured number.
By their numbers in this assay, from the lowest: compounds 4, 1 and 3 (each within the scatter of the next); then compound 2.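

In this assay, for the compounds shown here, compound 1 and compound 4 form the first pair that differs in one place only, giving a direct reading for this substitution: a 1.1-fold lower number from compound 1 to compound 4 (0.06 log units; within the scatter), which lies within the scatter. Chloro in place of hydrogen on an aromatic carbon, meta to a large group, therefore leaves phenyl and 3-chlorophenyl indistinguishable in this read-out, something compound 1, compound 2 and compound 3 could not show because their structures differ in more than one place. No measurement at hand bears on why the pair reads this way.

Open, going by these compounds, is whether this same place on the phenyl of compound 1 would read alike with an amine, a carboxylic acid or a methoxy group in place of hydrogen, or with chloro on another carbon of that ring. Also open, on these data alone, is whether chloro in place of hydrogen would give a comparable step on the differently substituted frameworks of compound 2 and compound 3.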